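A few compounds are considered here, and "the series" means these few. Any claim that something is new, unique, unknown or untested is made for them only; others in the source may bear on it.

Measured so far in a functional assay on ECa-109 cells (Homo sapiens) for antiproliferative activity, read by MTT assay, with a stated time of 48 h (on this read-out higher numbers stand for weaker inhibition and lower numbers for stronger inhibition), are two compounds:
- compound 1 `Cn1cc(C2=C(c3nn(CCCN4CCCCC4)c4ncccc34)C(=O)N(c3ccccc3)C2=O)c2ccccc21` with 12300 nM
- compound 2 `Cn1cc(C2=C(c3nn(CCn4ccnc4)c4ncccc34)C(=O)N(c3ccccc3)C2=O)c2ccccc21` with 8770 nM

Within the data shown here, compound 2 and compound 1 lie within the scatter of each other, so compound 2 stands level with the only other measured compound. Compound 3 `Cn1cc(C2=C(c3nn(CCCn4ccnc4)c4ncccc34)C(=O)N(c3ccccc3)C2=O)c2ccccc21` lengthens the chain of compound 2 with (1H-imidazol-1-yl)methyl in place of 1H-imidazol-1-yl on a saturated chain carbon, two bonds along the chain from an aromatic nitrogen as the difference: (1H-imidazol-1-yl)methyl in place of 1H-imidazol-1-yl on a saturated chain carbon, two bonds along the chain from an aromatic nitrogen. Among the measured compounds shown here, only one measured step bears on this, a 1.4-fold lower number from compound 1 to compound 2 (0.15 log units; within the scatter) at that same place, and it stayed within the scatter. For the measured compounds named here, no measured pair isolates the new change, so no direction can be given and no shift beyond the scatter is expected in this assay for now. The estimated step runs a 1.0-fold higher number from compound 2 to compound 3 (0.01 log units; within the scatter) and stays within the scatter. Compound 3 is estimated at 9000 nM with an expected range of 4500 nM to 18000 nM in this read-out.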

Compound 3, half-maximal inhibitory concentration: 1440 nM
For compound 3 the middle estimate is 6.3-fold (0.80 log units) above the measured one; the measured number lies below the stated range.
By their numbers in this assay, from the lowest: compound 3; then compounds 2 and 1 (each within the scatter of the next).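

In this assay, among these compounds, the chain length matters once the end group is held fixed: 3-(1H-imidazol-1-yl)propyl in place of 2-(1H-imidazol-1-yl)ethyl gives a 6.1-fold lower number from compound 2 to compound 3 (0.78 log units; beyond the scatter), the first step at this position to go beyond the scatter. With the chain length held, 1H-imidazol-1-yl in place of piperidin-1-yl gives an 8.5-fold lower number from compound 1 to compound 3 (0.93 log units; beyond the scatter), so the end group also counts, a separation the earlier step could not make with both features changing at once. Nothing available gives a reason for either step.

On these data alone, whether the trend continues with a longer chain, such as 4-(1H-imidazol-1-yl)butyl, remains open. As far as these compounds go, it is also open whether the imidazole itself is required, or whether another end group, such as a morpholine or a 1H-pyrazol-1-yl ring, would serve on the same chain.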